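A Pyrrolidine in Place of a Methyl Group

The source may hold more compounds than are shown below. What is called first, only, known or untested is meant among the compounds shown, and "the series" means these compounds.

Compound 3 `Cc1ncc(-c2nc(C(F)(F)F)sc2N2CCN(C(=O)Cn3nc(C)nc3C)[C@H](C)C2)cn1` is the starting point. Within the data shown here, in an assay on blood for inhibition of C-X-C chemokine receptor type 3 (Homo sapiens), with a stated time of 30 min (on this read-out lower numbers stand for stronger inhibition and higher numbers for weaker inhibition), compound 3 gives 610 nM, the second highest of the three numbers measured so far. Compound 1 `Cc1nc(-c2nc3ccccc3[nH]2)c(N2CCN(C(=O)Cn3cnc4cccnc43)[C@H](C)C2)s1` gives 1060 nM, and compound 1 and compound 3 lie within the usual scatter of each other. Compound 2 `Cc1ncc(-c2nc(C(F)(F)F)sc2N2CCN(C(=O)Cn3cnc4cccnc43)[C@H](C)C2)cn1` gives 104 nM; the only single-place step among these three, a 5.9-fold higher number from compound 2 to compound 3 (0.77 log units; beyond the scatter), concerns a different part of the molecule, the group on the saturated chain carbon bound to the carbonyl carbon.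

Compound 4 `Cc1nc(C)n(CC(=O)N2CCN(c3sc(C(F)(F)F)nc3-c3cnc(N4CCCC4)nc3)C[C@H]2C)n1` differs from compound 3 by pyrrolidin-1-yl in place of methyl on an aromatic carbon. Among the measured compounds shown here, no measured pair shows this change, so the one step on record does not bear on it, and nothing among the numbers says which way the result should move. The change in this assay is therefore expected to be a 1.0-fold lower number from compound 3 to compound 4 (0.01 log units; within the scatter), with a wide band of uncertainty around it. Compound 4 is estimated at 600 nM, somewhere between 200 nM and 1800 nM.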

Compound 4, half-maximal inhibitory concentration: 352 nM
The estimate for compound 4 lay 1.7-fold (0.23 log units) above the measured number, within the range that was stated.
By their numbers in this assay, from the lowest: compound 2; then compounds 4, 3 and 1 (each within the scatter of the next, the first and the last beyond it).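

In this assay, putting pyrrolidin-1-yl in place of methyl on the aromatic carbon between two ring nitrogen atoms gives a 1.7-fold lower number from compound 3 to compound 4 (0.24 log units; within the scatter), so the two numbers cannot be told apart. Among these compounds, this position therefore accepts pyrrolidin-1-yl, a group with a ring of its own, in place of methyl, with no effect on the number that stands beyond the scatter; the earlier compounds gave no reading here, since their one step concerned the group on the saturated chain carbon. Nothing on hand explains this result.

Still open, as far as these compounds go, is whether an open-chain amine such as dimethylamino, or a morpholine ring, would read the same at this position. Also open, from the compounds shown here alone, is whether pyrrolidin-1-yl would behave the same way alongside the group that compound 2 carries on the saturated chain carbon.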